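Halogen walk at the anilide ring: bromo to iodo

The compounds below may be only part of what the source reports. "The series", "measured", "known", "first", "only" and "open" are said of these compounds alone.

Compound 2 `O=C(Nc1cccc(Br)c1)C(Cl)Cl` holds the lowest of the two numbers recorded so far: in a functional assay on Bel-7402 cells (Homo sapiens) for antiproliferative activity, read by MTT assay, with a stated time of 72 h (on this read-out higher numbers stand for weaker inhibition and lower numbers for stronger inhibition), compound 2 gives 7720 nM, while compound 1 `O=C(Nc1cccc(Cl)c1)C(Cl)Cl` gives 44500 nM. Within the data shown here, the one step in hand is a 5.8-fold lower number from compound 1 to compound 2 (0.76 log units; beyond the scatter). Compound 3 `O=C(Nc1cccc(I)c1)C(Cl)Cl` differs from compound 2 by iodo in place of bromo on an aromatic carbon. Among the measured compounds shown here, no measured pair involves iodo, so the only step that bears on this change is the chloro-to-bromo exchange, which moved the number downward well beyond the scatter. For the measured compounds named here, a second exchange of the same kind is expected to move in the same direction, though a smaller move is assumed, as the single precedent does not show whether the trend continues at full strength. The expected step for compound 3 is a 2.2-fold lower number from compound 2 to compound 3 (0.34 log units; beyond the scatter). For compound 3 the estimate in this assay is 3500 nM, with a range from 1200 nM to 9000 nM.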

Compound 3, half-maximal inhibitory concentration: 5390 nM
Beside the measured number, compound 3's estimate is 1.5-fold (0.19 log units) below it; the measured number falls inside the stated range.
By their numbers in this assay, from the lowest: compounds 3 and 2 (each within the scatter of the next); then compound 1.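

Iodo in place of bromo on this aromatic carbon gives a 1.4-fold lower number from compound 2 to compound 3 (0.16 log units; within the scatter) in this assay, so the gain seen on leaving chloro does not extend measurably to the next halogen. Iodo in place of chloro gives an 8.3-fold lower number from compound 1 to compound 3 (0.92 log units; beyond the scatter), which places chloro apart from both heavier halogens, while bromo and iodo cannot be told apart at this position. No evidence on any property of these groups is available to account for this result.

The compounds shown contain only halogens at this position, so the effect of a methyl group, an amine or a carboxylic acid there remains open. Also open, on these data alone, is whether the separation of chloro from bromo and iodo would hold with the halogen elsewhere on the ring or with other changes to the rest of the core of compound 1.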